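This account rests on a few compounds, and the source may have more. Where it says the series, first, only, none or still open, it means among the compounds named here.

Measured compounds:
compound 1 `COc1cc2c(Oc3ccc(NC(=O)c4cn(-c5ccccc5C)nn4)cc3F)ccnc2cc1OCCCN1CCCCC1`, 1340 nM;
compound 2 `COc1cc2c(Oc3ccc(NC(=O)c4cn(-c5ccccc5C)nn4)cc3F)ccnc2cc1OCCCN1CCC(C)CC1`, 2380 nM;
compound 3 `COc1cc2c(Oc3ccc(NC(=O)c4cn(-c5ccccc5)nn4)cc3F)ccnc2cc1OCCCN1CCN(C)CC1`, 180 nM.

In a functional assay on HT-29 cells (Homo sapiens) for cytotoxicity, read by MTT assay, with a stated time of 72 h (on this read-out higher numbers stand for weaker inhibition and lower numbers for stronger inhibition), compound 3 gives the lowest number of the three, and its gap to compound 1 and to compound 2 lies beyond the scatter. Compound 4 `COc1cc2c(Oc3ccc(NC(=O)c4cn(-c5ccccc5C)nn4)cc3F)ccnc2cc1OCCCN1CCN(C)CC1` differs from compound 3 by methyl in place of hydrogen on an aromatic carbon, ortho to a large group, so that phenyl becomes 2-methylphenyl. Among the compounds with values here, the only single-change step measured, a 1.8-fold higher number from compound 1 to compound 2 (0.25 log units; within the scatter), concerns a methyl on a saturated ring carbon and so does not bear on this change; no measured pair isolates it. Compound 4 is therefore expected to stay close to compound 3, with a step of a 1.7-fold higher number from compound 3 to compound 4 (0.22 log units; within the scatter). Compound 4 is estimated at 300 nM, between 100 nM and 900 nM.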

Compound 4, half-maximal inhibitory concentration: 1430 nM
Compound 4: the middle estimate sits 4.8-fold (0.68 log units) below what was measured; measured number above the stated range.
By their numbers in this assay, from the lowest: compound 3; then compounds 1, 4 and 2 (each within the scatter of the next).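

In this assay, methyl in place of hydrogen on an aromatic carbon, ortho to a large group, turns phenyl into 2-methylphenyl and gives the first large single-change step (a 7.9-fold higher number from compound 3 to compound 4 (0.90 log units; beyond the scatter)). With 2-methylphenyl held constant, 4-methylpiperazin-1-yl in place of 4-methylpiperidin-1-yl gives a small step (a 1.7-fold lower number from compound 2 to compound 4 (0.22 log units; within the scatter)), and in place of piperidin-1-yl a smaller one (a 1.1-fold higher number from compound 1 to compound 4 (0.03 log units; within the scatter)). The compounds shown leave open whether fluoro or methoxy at this carbon would give a similar step, and whether phenyl with piperidin-1-yl would differ likewise. Nothing available accounts for the step from phenyl to 2-methylphenyl.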